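Dropping the aryl methyl from a benzoxazolone sigma-1 ligand

The source may hold more compounds than are shown below. What is called first, only, known or untested is meant among the compounds shown, and "the series" means these compounds.

Measured so far:
compound 1, `Cc1cccc(CN(C)CCCn2c(=O)oc3ccccc32)c1`: 1840 nM
compound 2, `CN(CCCCn1c(=O)oc2ccccc21)Cc1ccc(Cl)cc1`: 7.1 nM

In an assay on membranes from liver for displacement of a labelled ligand from Sigma non-opioid intracellular receptor 1 (Rattus norvegicus), read by scintillation counting (on this read-out lower numbers stand for stronger inhibition and higher numbers for weaker inhibition), compound 1 gives 1840 nM, the higher of the two numbers; compound 2 gives 7.1 nM, far lower and well beyond the scatter. Compound 3, `CN(CCCn1c(=O)oc2ccccc21)Cc1ccccc1`, is not yet measured. Relative to compound 1 the change is hydrogen in place of methyl on an aromatic carbon. Among the compounds with values here, no measured pair separates this single change, so its size is unknown. Since compound 1 gives the weaker number of the pair, a modest move toward stronger binding, a 3.1-fold lower number from compound 1 to compound 3 (0.49 log units; beyond the scatter), is expected, though it may stay within scatter. Compound 3 is estimated at 600 nM, between 100 nM and 4000 nM.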

Compound 3, inhibition constant: 223 nM
For compound 3 the middle estimate is 2.7-fold (0.43 log units) above the measured one; the range from low to high includes it.
By their numbers in this assay, from the lowest: compound 2; then compound 3; then compound 1.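

In this assay, the change from 3-methylphenyl to phenyl gives an 8.3-fold lower number from compound 1 to compound 3 (0.92 log units; beyond the scatter), the first measured size for this single change. On this aromatic carbon, meta to a large group, the methyl therefore goes with weaker binding than hydrogen, although this rests on one pair. Nothing available here explains the step.

Going by these compounds, it remains open whether a chlorine, a methoxy group or a fluorine at this position would behave like methyl or like hydrogen. On these data alone, compound 2 differs from compound 3 in more than one place, so the separate contributions of its chlorine and its longer chain also remain open.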